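A few compounds are considered here, and "the series" means these few. Any claim that something is new, unique, unknown or untested is made for them only; others in the source may bear on it.

So far a functional assay on L02 cells (Homo sapiens) for inhibition, read by Griess assay, with stated times of 1 h and 24 h (on this read-out higher numbers stand for weaker inhibition and lower numbers for stronger inhibition), has three results. Compound 1 `CCCc1nn(C)c2c(NC3CC3)nc(/C=C/c3cccnc3)nc12` gives 261000 nM, a real number. Compound 2 `CCCc1nn(C)c2c(NCc3ccc(F)cc3)nc(/C=C/c3ccc[n+]([O-])c3)nc12` gives < 40000 nM, which is only a limit of the assay. Compound 3 `CNc1nc(/C=C/c2ccccc2)nc2ccsc12` gives > 1000000 nM, also only a limit, and it stands at the weak end of the results so far.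

Compound 4 `Brc1ccc(CNc2nc(/C=C/c3ccccc3)nc3ccsc23)cc1` turns the methyl of compound 3 into 4-bromobenzyl: 4-bromophenyl in place of hydrogen on a saturated chain carbon bound to a nitrogen on an aromatic ring. Within the data shown here, no measured pair shows what this change does. Compound 2, on a different core, also carries a benzyl group on that nitrogen, and its limit is < 40000 nM. On that slim basis, a sizeable move toward stronger inhibition is expected, an estimated step of an at least 10-fold lower number from compound 3 to compound 4 (1.00 log units; beyond the scatter). Compound 4 is estimated at 100000 nM, within an expected range of 15000 nM to 700000 nM.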

Compound 4, half-maximal inhibitory concentration: > 1000000 nM
Compound 4 gave a limit, no number (the forecaster's own chance of this, stated with the estimate: 35%); middle value at least 10-fold (1.00 log units) away from the limit.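

Compound 3 and compound 4 each stop at a limit of the assay, and no step can be read between them. The compounds shown leave open whether methyl to 4-bromobenzyl changes inhibition at all.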